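Swapping a pyridinyl arm for methoxyphenyl in cytotoxicity

A few compounds are considered here, and "the series" means these few. Any claim that something is new, unique, unknown or untested is made for them only; others in the source may bear on it.

The study compares three compounds built on one shared core. Compound 1 `CCOc1ccc(/C=C2\S/C(=N\c3ccccc3)N(Cc3ccco3)C2=O)cc1` has no result in a toxicity assay on CHO cells (Cricetulus griseus) for cytotoxicity, read by MTT assay, with a stated time of 72 h; a higher number here means a weaker inhibitor, a lower number a stronger inhibitor; for compound 1 the entry reads "not determined" (no result reported). Compound 2 `O=C1/C(=C/c2ccccn2)S/C(=N\c2ccccc2)N1Cc1ccco1` was run in this assay and returns only a limit, > 250000 nM, which is a limit of the assay and not a number. Within the data shown here, compound 2 therefore stands at the edge of what this assay reports, the single anchor among the values being (the limit of > 250000 nM in this assay, at which 1 of the 2 values shown sits), while the other entry carries no number at all.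

Compound 3 `COc1ccc(/C=C2\S/C(=N\c3ccccc3)N(Cc3ccco3)C2=O)cc1` differs from compound 2 in one place: 4-methoxyphenyl in place of pyridin-2-yl on a double-bonded chain carbon bound to a double-bonded ring carbon. Among the measured compounds shown here, no step between measured compounds is known here, so the size of this move cannot be read from any measured pair. Compound 3 is expected to remain near that limit. The step that this estimate means, a number no higher from compound 2 to compound 3 (the limit leaves the size open), is expected to be none beyond the usual scatter. The estimate for compound 3 in this assay is 250000 nM, with a range from 50000 nM to 1000000 nM, and the assay is expected more likely than not to report only a limit once more.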

Compound 3, half-maximal inhibitory concentration: > 250000 nM
Compound 3: a limit, no number; the forecaster's own chance of this, stated with the estimate: 70%; the middle value sits exactly at the limit.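

In this assay compound 3 gives > 250000 nM, which is a limit of the assay and not a number. Compound 2 also returns only a limit, so no step can be read between compound 2 and compound 3. The compounds shown leave open whether 4-methoxyphenyl in place of pyridin-2-yl changes cytotoxicity at all.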